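The source may report more compounds than this note shows. Statements on the series, on what has been measured and on what is new or still open speak of the compounds shown alone.

Measured in an ADME assay on Vero cells (Chlorocebus sabaeus) for cytotoxicity, read by neutral red uptake, with a stated time of 48 h; a higher number here means a weaker inhibitor, a lower number a stronger inhibitor:
- Compound 1 (`CCCc1cn(Cc2ccccc2O)nn1`): > 20000 nM, a limit
- Compound 2 (`CCCCCc1c(CO)nnn1Cc1ccc2ccccc2c1`): > 20000 nM, a limit
- Compound 3 (`CC(C)=CCC/C(C)=C/Cn1cc(COc2ccccc2O)nn1`): > 20000 nM, a limit

Compound 1 has only a limit here and no number. It shares that reading with compound 2 and compound 3 (the limit of > 20000 nM in this assay, at which 3 of the 3 values shown sit), so no order can be drawn among them.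

Compound 4 (`Oc1ccccc1Cn1cc(-c2ccccc2)nn1`) comes from compound 1 by one change (phenyl in place of propyl on an aromatic carbon), phenyl in place of propyl on an aromatic carbon. Within the data shown here, no measured step shows what such a change does. In this assay no step beyond the scatter is expected, and no direction is favoured, given that compound 2 and compound 3 share the limit of compound 1 (the limit of > 20000 nM in this assay, at which 3 of the 3 values shown sit). The expected step is small (a number no higher from compound 1 to compound 4 (the limit leaves the size open)). Compound 4 is estimated at 20000 nM, with an expected range from 9000 nM to 40000 nM.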

Compound 4, half-maximal inhibitory concentration: > 20000 nM
Compound 4: only a limit was reported; the forecaster's own chance of this, stated with the estimate: 75%; the middle value lies on the limit itself.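

Compound 4 gives a limit, as compound 1 does, so no step between the two can be read: the limit of > 20000 nM in this assay, at which 4 of the 4 values shown sit.

The compounds shown leave open at what concentration, if any, each would give an actual number in this assay.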